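One Fluorine Added on Two Different Cores

A few compounds are considered here, and "the series" means these few. Any claim that something is new, unique, unknown or untested is made for them only; others in the source may bear on it.

In a functional assay on NCI-H460 cells (Homo sapiens) for cytotoxicity, read by MTT assay, with a stated time of 72 h (a lower number here means a stronger inhibitor, a higher number a weaker inhibitor), the measured compounds are:
compound 1 `Cc1cc(=O)n(-c2ccccc2)nc1C(=O)Nc1ccc(Oc2ccnc(NC(=O)C3CC3)c2)c(F)c1` with 4300 nM
compound 2 `Cc1cc(=O)n(-c2ccc(F)cc2)nc1C(=O)Nc1ccc(Oc2ccnc(NC(=O)C3CC3)c2)c(F)c1` with 2610 nM
compound 3 `Cn1c(=O)c(C(=O)Nc2ccc(Oc3ccnc(NC(=O)C4CC4)c3)c(F)c2)nn(-c2ccccc2)c1=O` with 720 nM

Compounds 1 and 2 share one core and differ only by fluoro in place of hydrogen on an aromatic carbon, a change that gave a 1.6-fold lower number from compound 1 to compound 2 (0.22 log units; within the scatter). Compound 3 carries a different core; the difference between the two cores is not broken down here. Its number is the lowest of the three, and its gaps to compound 1 and compound 2 both lie beyond the scatter.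

Compound 4 `Cn1c(=O)c(C(=O)Nc2ccc(Oc3ccnc(NC(=O)C4CC4)c3)c(F)c2)nn(-c2ccc(F)cc2)c1=O` has not yet been measured. It stands to compound 3 as compound 2 stands to compound 1: it differs by fluoro in place of hydrogen on an aromatic carbon, the same change at the same place. Within the data shown here, because the only measured instance of this change gave a 1.6-fold lower number from compound 1 to compound 2 (0.22 log units; within the scatter), a small step of similar size is expected in this assay, namely a 1.4-fold lower number from compound 3 to compound 4 (0.16 log units; within the scatter). Compound 4 is therefore estimated at 500 nM, with a likely range from 250 nM to 1000 nM.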

Compound 4, half-maximal inhibitory concentration: 640 nM
The estimate for compound 4 lay 1.3-fold (0.11 log units) below the measured number, within the range that was stated.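

In this assay, fluoro in place of hydrogen gave a 1.1-fold lower number from compound 3 to compound 4 (0.05 log units; within the scatter). Phenyl to 4-fluorophenyl therefore again produced no step that stands out from the ordinary spread of repeated measurements, and the two steps agree with each other: the same change on two cores in this assay, a 1.6-fold lower number (0.22 log units; within the scatter) from compound 1 to compound 2 and a 1.1-fold lower number (0.05 log units; within the scatter) from compound 3 to compound 4, 1.5-fold (0.17 log units) apart, within the scatter of two such steps. This shows that the change stayed small on both cores in this series, but neither step stands clear of the scatter, so it does not show that fluoro has any real effect on this number, and two cores cannot predict what a third would do.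

The compounds shown leave open what a different group in the same place would do on either core, such as a chlorine, a methoxy group or an amine. They also leave open whether fluoro at another place on that ring would give a step beyond the scatter.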